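The source may report more compounds than this note shows. Statements on the series, on what has been measured and on what is new or still open speak of the compounds shown alone.

The measured compounds are:
Compound 1 `O=C1NC(=O)/C(=C/C(c2ccc(-c3ccc4cccc(F)c4c3)[nH]c2=O)C2CC2)O1` gives 3850 nM in a physicochemical assay for solubility, measured as kinetic solubility, at pH 2; on this read-out lower numbers stand for lower solubility and higher numbers for higher solubility.
Compound 2 `CCC(CC)C(/C=C1\OC(=O)NC1=O)c1ccc(-c2ccc3cccc(F)c3c2)[nH]c1=O` gives 3680 nM in this assay.
Compound 3 `CC(C)C(c1ccc(-c2ccc3cccc(F)c3c2)[nH]c1=O)C1SC(=O)NC1=O` gives 11300 nM in this assay.

Among these three, compound 2 shows the lowest number in this assay, though compound 1 sits within the scatter of it, while compound 3 stands higher by a margin beyond the scatter. The move to compound 4 `O=C1NC(=O)/C(=C/C(Cc2ccccc2)c2ccc(-c3ccc4cccc(F)c4c3)[nH]c2=O)O1` is the change (benzyl in place of pentan-3-yl on a saturated chain carbon bound to an aromatic carbon and a double-bonded chain carbon). Going by the values given here, one measured step touches the same place: a 1.0-fold lower number from compound 1 to compound 2 (0.02 log units; within the scatter). That step exchanged one saturated group for another and left the read-out essentially unmoved. Among the compounds with values here, no measured step exchanges a saturated group for one bearing an aromatic ring, so the effect of benzyl at this place is untested. Because the step of a 1.0-fold lower number from compound 1 to compound 2 (0.02 log units; within the scatter) is flat, a step of a 1.2-fold lower number from compound 2 to compound 4 (0.09 log units; within the scatter) is expected, within or only just beyond the scatter, and leaning slightly lower. Compound 4 is estimated at 3000 nM, with a range from 1200 nM to 7500 nM.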

Compound 4, solubility: 900 nM
Compound 4: middle estimate off by 3.3-fold (0.52 log units), on the high side; measured number outside the range, below it.
By their numbers in this assay, from the lowest: compound 4; then compounds 2 and 1 (each within the scatter of the next); then compound 3.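

In this assay (this assay), the saturated chain carbon bound to an aromatic carbon and a double-bonded chain carbon turns out to be a place where the number can move. Benzyl in place of pentan-3-yl gives a step (a 4.1-fold lower number from compound 2 to compound 4 (0.61 log units; beyond the scatter)) and benzyl in place of cyclopropyl gives another (a 4.3-fold lower number from compound 1 to compound 4 (0.63 log units; beyond the scatter)), both beyond the scatter. The earlier step here (a 1.0-fold lower number from compound 1 to compound 2 (0.02 log units; within the scatter)) exchanged one saturated group for another, so the flatness it showed does not carry over to a group bearing an aromatic ring.

No measurement given here bears on the origin of this drop. Going by these compounds, it also remains open how the number would respond to a phenyl group at this place, or to a benzyl carrying an amine or a carboxylic acid.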